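Swapping one halogen for another on the pendant phenyl ring

This account rests on a few compounds, and the source may have more. Where it says the series, first, only, none or still open, it means among the compounds named here.

Measured so far in a functional assay on CHO cells for agonist activity at adenosine receptor A1 (Homo sapiens), read by fluorescence and ERK phosphorylation, with stated times of 30 min and 1.5 h, tested at 3 uM; on this read-out lower numbers stand for a weaker effect and higher numbers for a stronger effect at the one concentration tested:
compound 1, `Nc1scc(-c2ccccc2F)c1C(=O)c1ccccc1`: 55%
compound 2, `Nc1scc(-c2cccc(F)c2)c1C(=O)c1ccccc1`: 51%
compound 3, `Nc1scc(-c2cccc(Cl)c2)c1C(=O)c1ccccc1`: 45%

All three share the same core and differ only in the halogen on the phenyl ring attached to it. On these numbers compound 3 is not set apart from its neighbours: the step of a number 10 percentage points lower from compound 1 to compound 3 (within the scatter) and the step of a number 6 percentage points lower from compound 2 to compound 3 (within the scatter) both sit inside the ordinary scatter, as does the step of a number 4 percentage points lower from compound 1 to compound 2 (within the scatter) between the two fluoro compounds.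

Compound 4, `Nc1scc(-c2cccc(Br)c2)c1C(=O)c1ccccc1`, has not yet been measured. It differs from compound 3 in one place: bromo in place of chloro on an aromatic carbon. Going by the values given here, the only measured step that speaks to such a halogen swap is the step of a number 6 percentage points lower from compound 2 to compound 3 (within the scatter), which did not rise above the scatter. A change of one halogen for another on this ring is therefore expected to leave the read-out in this assay essentially where compound 3 left it, with no step beyond the scatter in either direction.

The expected step is a number 1 percentage points lower from compound 3 to compound 4 (within the scatter). Compound 4 is estimated at 44%, with a likely range from 30% to 58%.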

Compound 4, a percentage reported as activity, at one concentration (the size of the read-out at that concentration, not a potency): 67%
Beside the measured number, compound 4's estimate is 23 percentage points below it; measured number outside the range, above it.
By their numbers in this assay, from the lowest: compounds 3, 2 and 1 (each within the scatter of the next); then compound 4.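

In this assay, the earlier fluoro and chloro compounds suggested that a halogen swap on this ring changes little, but a number 22 percentage points higher from compound 3 to compound 4 (beyond the scatter) shows that bromo in place of chloro can produce a step beyond the scatter. The bromo compound also stands apart from both fluoro compounds, with a number 16 percentage points higher from compound 2 to compound 4 (beyond the scatter) and a number 12 percentage points higher from compound 1 to compound 4 (beyond the scatter) as the steps, while those two and the chloro compound remain within the scatter of one another. Nothing available explains why bromo behaves differently from chloro here.

As far as these compounds go, it remains open whether iodo, methyl or methoxy at this place on the ring would hold, raise or lower the read-out. These figures come from one concentration, so they show a stronger effect for compound 4 than for compound 3 at that concentration only and leave open how the two would compare at any other.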